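The compounds below may be only part of what the source reports. "The series", "measured", "known", "first", "only" and "open" are said of these compounds alone.

Compound 2 `COC[C@H]1C[C@@](CC(C)C)(C(=O)O)N(C(=O)c2ccc(C(C)(C)C)c(OC)c2)[C@H]1C(=O)OC` stands at the edge of what an ADME assay on Huh-5-2 cells (Homo sapiens) for cytotoxicity, with a stated time of 3 days (a lower number here means that less compound is tolerated, a higher number that more compound is tolerated), can report. In this assay compound 2 gives > 120000 nM, which is a limit of the assay and not a number. Compound 1 `COC[C@H]1C[C@@](CC(C)C)(C(=O)O)N(C(=O)c2ccc(C(C)(C)C)c(OC)c2)[C@H]1COC` is in the same position. In this assay compound 1 gives > 120000 nM, again a limit rather than a number. For the measured compounds named here, the one measured step, a step that the two limits leave unreadable from compound 1 to compound 2, is therefore unreadable because of the limit of > 120000 nM in this assay, at which 2 of the 2 values shown sit. Compound 3 `COC[C@H]1C[C@@](CC(C)C)(C(=O)O)N(C(=O)c2ccc(C(C)(C)C)c(OC)c2)[C@H]1CNC(C)=O` differs from compound 2 in one place: acetamidomethyl in place of methoxycarbonyl on a saturated ring carbon. Going by the values given here, no readable step bears on this change, since the only step on record cannot be sized. One therefore expects a step that the limit leaves unreadable from compound 2 to compound 3, that is, no change beyond the scatter, with compound 3 most likely sitting at the limit again. The estimate for compound 3 in this assay is 150000 nM, with a range from 60000 nM to 400000 nM.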

Compound 3, half-maximal cytotoxic concentration: > 120000 nM
Compound 3: only a limit was reported; the forecaster's own chance of this, stated with the estimate: 80%; the middle value is on the limit's open side.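

No step among compound 1, compound 2 and compound 3 can be read, because each stands at a limit and not at a number: the limit of > 120000 nM in this assay, at which 3 of the 3 values shown sit.

The compounds shown leave open whether these three differ at all in this assay, and at what concentration any of them would become cytotoxic.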